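Bromo for acetamido on the sulfonyl aryl ring

This account rests on a few compounds, and the source may have more. Where it says the series, first, only, none or still open, it means among the compounds named here.

Measured so far:
compound 1 `CC(=O)Nc1ccc(S(=O)(=O)N2c3ccccc3CCC2C)cc1` gives 52000 nM in an ADME assay on L6 cells (Rattus norvegicus) for cytotoxicity; on this read-out higher numbers stand for weaker inhibition and lower numbers for stronger inhibition
compound 2 `CC1CCc2ccccc2N1S(=O)(=O)c1ccccc1` gives 70000 nM
compound 3 `CC1CCc2ccccc2N1S(=O)(=O)c1ccc(N)cc1` gives 35300 nM

All three numbers sit close together, and every step among them stays within the scatter: a 1.3-fold higher number from compound 1 to compound 2 (0.13 log units; within the scatter), a 1.5-fold lower number from compound 1 to compound 3 (0.17 log units; within the scatter), and a 2.0-fold lower number from compound 2 to compound 3 (0.30 log units; within the scatter). Compound 1 stands second highest of the three, nearest to compound 2 and furthest from compound 3, with both gaps within the scatter, so no order among them can be read from these numbers.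

Compound 4 `CC1CCc2ccccc2N1S(=O)(=O)c1ccc(Br)cc1` is the next member, differing from compound 1 as follows: bromo in place of acetamido on an aromatic carbon. The change sits on an aromatic carbon of a six-membered aromatic ring of carbon only, para to a large group.

Among the measured compounds shown here, no measured step puts bromo at this carbon. For the measured compounds named here, the steps that bear on it only indirectly are the removal of acetamido, a 1.3-fold higher number from compound 1 to compound 2 (0.13 log units; within the scatter), and the exchange of hydrogen for amino there, a 2.0-fold lower number from compound 2 to compound 3 (0.30 log units; within the scatter), both within the scatter. Changing the group at this position has so far moved the number by no more than the scatter, so for compound 4 no step beyond the scatter is expected in either direction, a 1.1-fold higher number from compound 1 to compound 4 (0.02 log units; within the scatter). Compound 4 is therefore estimated at 55000 nM, with a range from 25000 nM to 120000 nM.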

Compound 4, half-maximal inhibitory concentration: 7360 nM
Estimate against measurement, compound 4: 7.5-fold (0.87 log units) above; measured number below the stated range.
By their numbers in this assay, from the lowest: compound 4; then compounds 3, 1 and 2 (each within the scatter of the next).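

In this assay this position is no longer flat: bromo stands apart from all three earlier groups, with a 7.1-fold lower number from compound 1 to compound 4 (0.85 log units; beyond the scatter) against acetamido, a 4.8-fold lower number from compound 3 to compound 4 (0.68 log units; beyond the scatter) against amino and a 9.5-fold lower number from compound 2 to compound 4 (0.98 log units; beyond the scatter) against hydrogen on the same aromatic carbon. Compound 1, compound 2 and compound 3 remain within the scatter of one another, so the earlier lack of separation at this carbon held only for acetamido, amino and hydrogen and does not extend to bromo. Nothing measured here accounts for the separation of compound 4 from the others.

As far as these compounds go, whether the lower number belongs to bromo alone or also appears with chloro, fluoro, iodo, methyl or trifluoromethyl at this carbon stays open, and these compounds cannot show whether a halogen is required. From the compounds shown here alone, it is equally open whether bromo at another carbon of the same ring, or bromo combined with a change in the shared core, would give a comparable step.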